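The compounds below may be only part of what the source reports. "The series", "measured", "known", "first", "only" and "open" are said of these compounds alone.

Among the measured compounds shown here, the three compounds measured so far share one core. Compound 1 is `CCOC(=O)c1csc(-c2nc3ccccc3n2Cc2ccccc2)n1`, compound 2 is `CCOC(=O)c1csc(-c2nc3ccccc3n2CC)n1`, and compound 3 is `Cc1nc(-c2nc3ccccc3n2Cc2ccccc2)sc1C(=O)O`. All were tested in a functional assay on MCF7 cells (Homo sapiens) for cytotoxicity, read by MTT assay, with a stated time of 24 h; a lower number here means a stronger inhibitor, a higher number a weaker inhibitor. In this assay compound 1 gives only a limit of the measurement, > 20000 nM. Compound 2 likewise reaches only a limit, > 20000 nM. Compound 3 also stands at a limit, > 20000 nM, so it cannot be ranked against the other two. The three values sit together, as the limit of > 20000 nM in this assay, at which 3 of the 3 values shown sit, shows. For the measured compounds named here, the single step between measured compounds differing in one place, a step that the two limits leave unreadable from compound 1 to compound 2, cannot be read in size, since both of its ends are limits.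

Compound 4, not yet measured, is `Cc1nc(-c2nc3ccccc3n2Cc2ccccc2)sc1C(=O)NC1CCCCC1`. It differs from compound 3 by cyclohexylamino in place of hydroxy on a carbonyl carbon. Going by the values given here, no measured step touches a carbonyl carbon, so none bears directly on this change, and the only step available is unreadable. The expectation therefore rests on where compound 3 stands. Compound 4 is expected to give 25000 nM, within 5000 nM to 60000 nM. For compound 4 the step this estimate means, a step that the limit leaves unreadable from compound 3 to compound 4, is expected to lie within the scatter, with a good chance that only a limit is reported once more.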

Compound 4, half-maximal inhibitory concentration: 5230 nM
Compound 4: middle estimate off by 4.8-fold (0.68 log units), on the high side; low and high end bracket the measured number.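

Among the compounds shown here, until now, no compound in this assay had given a number, so this position on the carbonyl carbon is the first place where a change can be read: cyclohexylamino in place of hydroxy gives an at least 3.8-fold lower number from compound 3 to compound 4 (0.58 log units; beyond the scatter). Compound 3 gives only a limit, > 20000 nM, and the true step may be larger than the one that can be stated. Compound 4 is also the only compound shown with a measured number rather than a limit: the limit of > 20000 nM in this assay, at which 3 of the 4 values shown sit.

A single amide cannot show whether the gain comes from the six-membered ring of carbon or from replacing hydroxy with any amine, and a plain amino group or a methylamino group on the same carbonyl carbon would help separate the two. Also open, on these data alone, is whether methyl in place of phenyl on the saturated chain carbon bound to the aromatic nitrogen changes the activity of the amide, where such a step might be read as a number rather than being hidden by two limits.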